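Microsomal half-life: heterocycle swap from compound 2 to compound 3

The source may report more compounds than this note shows. Statements on the series, on what has been measured and on what is new or still open speak of the compounds shown alone.

Measured so far:
- compound 1, `CCn1ncc2c(F)cc(-c3ccc(C(CC)(CC)c4ncn(C)n4)c(=O)[nH]3)cc21`, which in an ADME assay on microsomes from liver (Mus musculus) for metabolic stability (a higher number here means that the compound lasts longer, a lower number that the compound disappears faster), gives > 3 h; this is a limit of the assay, not a number.
- compound 2, `CC(C)C(c1ccc(-c2ccc3cccc(F)c3c2)[nH]c1=O)N1CCN/C1=N\C#N`, which in this assay gives 0.207 h.

Among the compounds with values here, compound 2 thus carries the only numerical value; the other entry sits at the assay limit (the limit of > 3 h in this assay, at which 1 of the 2 values shown sits). Within the data shown here, compound 1 and compound 2 differ in more than one place, so no single-change step between measured compounds can be drawn from them.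

Compound 3, `Cc1c[nH]c(C(c2ccc(-c3ccc4cccc(F)c4c3)[nH]c2=O)C(C)C)n1`, awaits measurement. It departs from compound 2 in a single place: a group of 6 heavy atoms (4 carbon, 2 nitrogen; one five-membered aromatic ring with 2 hetero atoms) in place of a group of 8 heavy atoms (4 carbon, 4 nitrogen; one five-membered non-aromatic ring with 2 hetero atoms), on a saturated chain carbon bound to an aromatic carbon and a saturated chain carbon. The group that leaves carries the double bond and the triple bond outside aromatic rings; the group that enters is 4-methyl-1H-imidazol-2-yl.

Among the measured compounds shown here, no measured step informs this change. A modest step in this assay is expected, of uncertain direction and possibly within the scatter. Compound 3 is expected to give about 0.3 h, estimated between 0.1 h and 0.9 h. That estimate implies an expected step of a 1.4-fold higher number from compound 2 to compound 3 (0.16 log units; within the scatter).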

Compound 3, half-life: < 0.0667 h
Compound 3: a limit, no number; the forecaster's own chance of this, stated with the estimate: 5%; middle value at least 4.4-fold (0.65 log units) away from the limit.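

Within the data shown here, this is the first step between measured compounds, and it shows that the saturated chain carbon bound to an aromatic carbon and a saturated chain carbon is not a silent place in this assay for this change. On these data alone, putting 4-methyl-1H-imidazol-2-yl in place of the non-aromatic ring group gives an at least 3.1-fold lower number from compound 2 to compound 3 (0.49 log units; beyond the scatter) and so fixes the direction of the step, while its full size stays unknown. Compound 3 gives < 0.0667 h which is a limit of the assay and not a number, the lowest entry among those shown: the limit of < 0.0667 h in this assay, at which 1 of the 3 values shown sits.

The compounds shown leave open whether the lower number goes with the aromatic ring of 4-methyl-1H-imidazol-2-yl, with its methyl, or with the loss of the nitrile-bearing ring group, and they give no cause for it. Among these compounds, an unsubstituted imidazol-2-yl, a dimethylamine or a carboxylic acid on the same carbon would test how far the result holds for other groups, while compound 1 differs from the others in more than one place and sets no step.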